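Shortening the Ester Chain on a Shared Core

The compounds below may be only part of what the source reports. "The series", "measured", "known", "first", "only" and "open" are said of these compounds alone.

Three measured compounds share one core and differ only in the group attached to a carbonyl carbon. Compound 1 `CCCCOC(=O)[C@@H](N)CCC(=O)NCCSC(=O)c1ccccc1` carries a phenyl there, compound 2 `CCCCOC(=O)[C@@H](N)CCC(=O)NCCSC(=O)C(C)(C)C` a tert-butyl, and compound 3 `CCCCOC(=O)[C@@H](N)CCC(=O)NCCSC(C)=O` a methyl. In an ADME assay on liver for metabolic stability, with liver carboxylesterase 1 (Homo sapiens) as the target (on this read-out lower numbers stand for a shorter-lived compound and higher numbers for a longer-lived compound), compound 1 gives 0.167 h. In the same assay compound 2 gives 0.167 h, and compound 3 gives 0.167 h. The three steps between them tell the same story: no change at the digits printed from compound 1 to compound 2 (within the scatter), no change at the digits printed from compound 1 to compound 3 (within the scatter) and no change at the digits printed from compound 2 to compound 3 (within the scatter). Within the data shown here, compound 2 therefore stands level with compounds 1 and 3, with no measured compound standing apart from the others.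

Compound 4 `CCCOC(=O)[C@@H](N)CCC(=O)NCCSC(=O)C(C)(C)C` changes compound 2 at a different spot: hydrogen in place of methyl on a saturated chain carbon, three bonds along the chain from an oxygen next to a carbonyl group. Among the measured compounds shown here, no measured step alters this chain, so no direct precedent exists for it. The measured steps bear on it only indirectly, showing that the half-life of this core has so far stayed put while one group was swapped among three quite different sizes. With nothing pointing to a shift, the expected step from compound 2 to compound 4 is none beyond the scatter, that is no change at the digits printed from compound 2 to compound 4 (within the scatter). Compound 4 is accordingly estimated at 0.167 h, with a range from 0.08 h to 0.35 h.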

Compound 4, half-life: 0.167 h
Estimate against measurement, compound 4: no gap at the digits printed, and the stated range covers the measured number.
By their numbers in this assay, from the lowest: compounds 1, 2, 3 and 4 (each within the scatter of the next).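

In this assay, the step from butyl to propyl on the ester chain gives no change at the digits printed from compound 2 to compound 4 (within the scatter), so the half-life holds at a second place on the shared core as well as at the group on the carbonyl carbon. Among these compounds, the earlier compounds changed only that carbonyl group and kept the butyl chain throughout, so they could say nothing about this chain directly; here, removing one carbon from it leaves the reading level with the other three compounds. No measurement at hand explains why this change leaves the half-life where it is.

As far as these compounds go, this single step was taken with tert-butyl on the carbonyl carbon, so it remains open whether the same shortening would read the same with the phenyl of compound 1 or the methyl of compound 3 in that place. Also open, from the compounds shown here alone, is how the half-life would respond to an ethyl or methyl ester, to a longer chain such as hexyl, to a branched chain such as isopropyl, or to a free carboxylic acid in place of the ester.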